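This account rests on a few compounds, and the source may have more. Where it says the series, first, only, none or still open, it means among the compounds named here.

Going by the values given here, compound 1 `CN(C)CCN(CCN(C)C)c1cccc(C(=O)N2CCc3ccc(OS(N)(=O)=O)cc3C2)c1` is one of two compounds measured so far in an assay on HEK293 cells for inhibition of Steryl-sulfatase (Homo sapiens), tested at 0.1 uM; on this read-out higher numbers stand for a stronger effect at the one concentration tested and lower numbers for a weaker effect. In this assay compound 1 gives 0%, which is the lowest of the two numbers on hand. The other measured compound, compound 2 `NS(=O)(=O)Oc1ccc2c(c1)CN(C(=O)c1ccc(N3CCN(c4ncccn4)CC3)cc1)CC2`, gives 14.7% in this assay, a number higher than that of compound 1 by more than the usual scatter of this kind of measurement. Compound 3 `CCN(Cc1cccnc1)c1cccc(C(=O)N2CCc3ccc(OS(N)(=O)=O)cc3C2)c1` has not yet been measured. It differs from compound 1 in a single place: ethyl((pyridin-3-yl)methyl)amino in place of bis(2-(dimethylamino)ethyl)amino on an aromatic carbon. Among the compounds with values here, no pair of measured compounds that differ in only one place is available, so nothing anchors how much this kind of change can move the read-out. Because compound 1 gives 0%, the read-out can hardly move downward. The step is expected to be small, a number 8 percentage points higher from compound 1 to compound 3 (within the scatter), likely within the scatter. Compound 3 is therefore expected to give about 8%, within a range of 0% to 28%.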

Compound 3, a percentage reported as inhibition, at one concentration (the size of the read-out at that concentration, not a potency): 14.3%
The estimate for compound 3 lay 6.3 percentage points below the measured number; the range from low to high includes it.
By their numbers in this assay, from the lowest: compound 1; then compounds 3 and 2 (each within the scatter of the next).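

Under this assay the step is a number 14.3 percentage points higher from compound 1 to compound 3 (beyond the scatter) when ethyl((pyridin-3-yl)methyl)amino takes the place of bis(2-(dimethylamino)ethyl)amino on this aromatic carbon, meta to a large group. This shows that the group at this position can lift the read-out off the floor while the rest of the molecule stays the same, although the effect at this one concentration remains modest. The swap removes a group with no ring and brings in one with a six-membered aromatic ring, but no measurement on hand explains the step.

Going by these compounds, it remains open whether the pyridine ring matters in itself, which a benzyl group in its place, or a simple ethylamino group without the ring, would help to settle. On these data alone, how a morpholine or a carboxylic acid at this position would read also remains open.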